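Working notes: the step from compound 1 to compound 4

A few compounds are considered here, and "the series" means these few. Any claim that something is new, unique, unknown or untested is made for them only; others in the source may bear on it.

Among the measured compounds shown here, in a functional assay on the whole organism for antagonist activity, with Rattus norvegicus as the target (a lower number here means that less compound is needed, a higher number that more compound is needed for the effect), compound 1 `c1ccc2c(c1)CC2CCCN1CCN(c2cccc3c2OCCO3)CC1` gives 0.18 mg/kg, the lowest of the three numbers measured so far. Compound 2 `c1ccc2c(c1)CC2CCCCN1CCN(c2cccc3c2OCCO3)CC1` gives 1.43 mg/kg, and compound 3 `c1ccc2c(c1)CCCCC2CCN1CCN(c2cccc3c2OCCO3)CC1` gives 4.26 mg/kg. Compound 4 `Clc1cccc2c1CC2CCN1CCN(c2cccc3c2OCCO3)CC1` has not yet been measured. Its difference from compound 1 is a group of 9 heavy atoms (8 carbon, 1 chlorine; one four-membered non-aromatic ring of carbon only, one six-membered aromatic ring of carbon only) in place of a group of 9 heavy atoms (9 carbon; one four-membered non-aromatic ring of carbon only, one six-membered aromatic ring of carbon only), on a saturated chain carbon, two bonds along the chain from an amine nitrogen in a ring. The entering group carries chlorine, and the place is a saturated chain carbon, two bonds along the chain from an amine nitrogen in a ring.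

For the measured compounds named here, the one measured step that bears on this change is a 7.9-fold higher number from compound 1 to compound 2 (0.90 log units; beyond the scatter). It also replaces a group holding one four-membered non-aromatic ring and one six-membered aromatic ring, and it lies beyond the scatter. Going by the values given here, no measured compound carries chlorine, and no measured step shows this replacement directly, so the size of the coming step is poorly fixed. The only such replacement measured from compound 1 raised the number, and compound 1 already holds the lowest value, so a rise is the more likely direction, though one of uncertain size. The expected step is a 2.8-fold higher number from compound 1 to compound 4 (0.44 log units; beyond the scatter), a modest estimate. For compound 4 the estimated value in this assay is 0.5 mg/kg, with an expected range of 0.09 mg/kg to 2.8 mg/kg.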

Compound 4, dose for 50% inhibition: 1.13 mg/kg
Estimate against measurement, compound 4: 2.3-fold (0.35 log units) below; the range from low to high includes it.
By their numbers in this assay, from the lowest: compound 1; then compounds 4 and 2 (each within the scatter of the next); then compound 3.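

In this assay the group with chlorine, of 9 heavy atoms, replaces the all-carbon group of 9 heavy atoms on a saturated chain carbon, two bonds along the chain from an amine nitrogen in a ring, and this gives a 6.3-fold higher number from compound 1 to compound 4 (0.80 log units; beyond the scatter) with no change in the heavy-atom count. Together with a 7.9-fold higher number from compound 1 to compound 2 (0.90 log units; beyond the scatter) this makes two measured replacements of the group on the chain of compound 1, at two different places on that chain, and both raise the number beyond the scatter, so neither step improves on compound 1 in this assay. The compounds shown carry no measurement that explains the rise, and no cause can be assigned to it.

How much of the step belongs to the chlorine itself, and how much to the rest of the replacement, stays open, as the compounds shown do not separate the two. Also open, from the compounds shown here alone, is whether fluorine or a methoxy group in place of the chlorine, or a longer chain with the chlorine kept, would bring the number back towards that of compound 1.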